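This account rests on a few compounds, and the source may have more. Where it says the series, first, only, none or still open, it means among the compounds named here.

Of the compounds shown here, three with a shared core have been measured in a functional assay on CHO-K1 cells for antagonist activity at adenosine receptor A1 (Homo sapiens), read by a beta-galactosidase reporter and cAMP accumulation, with stated times of 15 min and 6 h; on this read-out higher numbers stand for weaker inhibition and lower numbers for stronger inhibition. Compound 1 `Cn1cnc(-c2nc(N)c3cc(Cc4ccccc4)sc3n2)c1` gives 2330 nM, compound 2 `N#Cc1cccc(-c2nc(N)c3cc(Cc4ccccc4)sc3n2)c1` gives 222 nM, and compound 3 `Nc1nc(-c2cccnc2)nc2sc(Cc3ccccc3)cc12` gives 1420 nM. Compound 3 thus stands second highest of the three, with compound 1 within the scatter of it and compound 2 set apart by a 6.4-fold higher number from compound 2 to compound 3 (0.81 log units; beyond the scatter). Compound 4 `Nc1nc(-c2cccc(Cl)n2)nc2sc(Cc3ccccc3)cc12` carries 6-chloropyridin-2-yl in place of pyridin-3-yl on an aromatic carbon, on an aromatic carbon between two ring nitrogen atoms. The measured steps of a 1.6-fold lower number from compound 1 to compound 3 (0.22 log units; within the scatter) and a 6.4-fold higher number from compound 2 to compound 3 (0.81 log units; beyond the scatter) show that exchanging the aryl group shifts this assay modestly at most, but none of them introduces a chlorine, so the direction is uncertain. A modest step of a 1.8-fold lower number from compound 3 to compound 4 (0.25 log units; within the scatter) is expected, putting compound 4 at an estimated 800 nM in this assay, within 200 nM to 3200 nM.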

Compound 4, inhibition constant: > 1000 nM
Compound 4: only a limit was reported; the forecaster's own chance of this, stated with the estimate: 5%; at least 1.2-fold (0.09 log units) between middle value and limit.
By their numbers in this assay, from the lowest: compound 2; then compounds 3 and 1 (each within the scatter of the next).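

In this assay compound 4 is reported only as a limit, > 1000 nM. Going by these compounds alone, with 6-chloropyridin-2-yl on this aromatic carbon between two ring nitrogen atoms, the one readable step is an at least 4.5-fold higher number from compound 2 to compound 4 (0.65 log units; beyond the scatter), so compound 2, with 3-cyanophenyl, keeps the lowest number of the four. The steps to compound 4 from compound 3 and from compound 1 cannot be read, because the result is bounded on one side only: the limit of > 1000 nM in this assay, at which 1 of the 4 values shown sits.

The compounds shown leave open whether 6-chloropyridin-2-yl differs at all from pyridin-3-yl here. They also leave open how a plain phenyl group or a methoxyphenyl group would read at this carbon.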